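From aryl amide to benzyl amide: an untested step

A few compounds are considered here, and "the series" means these few. Any claim that something is new, unique, unknown or untested is made for them only; others in the source may bear on it.

Compound 1 `COc1cc(-c2nnc(SCC(=O)c3ccccc3F)n2N)cc(OC)c1OC` gives 10800 nM in a functional assay on HCT-116 cells (Homo sapiens) for antiproliferative activity, read by MTT assay, with a stated time of 48 h; on this read-out higher numbers stand for weaker inhibition and lower numbers for stronger inhibition. Compound 2 `COc1ccc(C(=O)CSc2nnc(-c3cc(OC)c(OC)c(OC)c3)n2N)cc1` gives 1240 nM. Compound 3 `COc1cc(-c2nnc(SCC(=O)Nc3ccccc3C)n2N)cc(OC)c1OC` reaches only the limit of the measurement, > 100000 nM, so no number is known for it.

All three share a core and differ only in the group attached to the carbonyl carbon. The two ketones, compounds 1 and 2, give measured numbers, and the step of an 8.7-fold lower number from compound 1 to compound 2 (0.94 log units; beyond the scatter) shows the 4-methoxyphenyl ketone as the stronger of the pair. Turning the ketone into an amide cost much: an at least 9.2-fold higher number from compound 1 to compound 3 (0.96 log units; beyond the scatter) and an at least 80-fold higher number from compound 2 to compound 3 (1.90 log units; beyond the scatter), where the value of compound 3 sits at the limit of > 100000 nM in this assay, at which 1 of the 3 values shown sits.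

Compound 4 `COc1cc(-c2nnc(SCC(=O)NCc3ccc(Cl)cc3)n2N)cc(OC)c1OC` keeps the amide and changes only the group on its nitrogen: 4-chlorobenzyl in place of 2-methylphenyl on an amide-type nitrogen. Within the data shown here, no measured step alters this position, so the two amide steps are the only guide, and they place the amides far off the measurable range. Compound 4 is therefore expected to stay weak, with an at least 1.2-fold lower number from compound 3 to compound 4 (0.09 log units; that floor lies within the scatter), and is estimated at 80000 nM (range 15000 nM to 300000 nM), quite possibly again only a limit.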

Compound 4, half-maximal inhibitory concentration: > 100000 nM
Compound 4: only a limit was reported; the forecaster's own chance of this, stated with the estimate: 55%; middle value at least 1.2-fold (0.09 log units) away from the limit.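

Replacing 2-methylphenyl with 4-chlorobenzyl on the amide nitrogen does not bring activity into the measurable range in this assay, so the weak result is not confined to the 2-methylphenyl amide. Both ketones keep a clear lead over this second amide, with an at least 80-fold higher number from compound 2 to compound 4 (1.90 log units; beyond the scatter) and an at least 9.2-fold higher number from compound 1 to compound 4 (0.96 log units; beyond the scatter). The step between the two amides cannot be read, because both stand at a limit: the limit of > 100000 nM in this assay, at which 2 of the 4 values shown sit.

On these data alone, whether a 4-methoxyphenyl group on the amide nitrogen, or a longer chain such as 2-phenylethyl, would bring an amide back into the measurable range remains open. Also open, as far as these compounds go, is how a 4-chlorophenyl ketone would compare with compound 2.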